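Fluorocyclopropyl amide on the shared bicyclic diamine core

The source may hold more compounds than are shown below. What is called first, only, known or untested is meant among the compounds shown, and "the series" means these compounds.

Compound 2 `CC(C)C(=O)N1CC2CC(C1)N2` gives 130 nM in an assay on SH-EP1 cells for displacement of a labelled ligand from Neuronal acetylcholine receptor; alpha4/beta2 (Homo sapiens), read by scintillation counting; on this read-out lower numbers stand for stronger inhibition and higher numbers for weaker inhibition. Of the three numbers in hand, compound 2 holds the second highest. The nearest number belongs to compound 3 `O=C(C1CC=CC1)N1CC2CC(C1)N2`, which gives 51 nM in this assay, a lower number beyond the scatter. The furthest belongs to compound 1 `O=C(C1CC1)N1CC2CC1CN2`, built on a different core, which gives 2800 nM in this assay, a far higher number beyond the scatter.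

Compound 4 `O=C([C@H]1C[C@@H]1F)N1CC2CC(C1)N2` has not been measured. It differs from compound 2 by 2-fluorocyclopropyl in place of isopropyl on a carbonyl carbon. Among the measured compounds shown here, no pair of measured compounds shows this change, and compound 1, the only measured compound with a three-membered ring on the carbonyl carbon, sits on another core, so its number is no guide. The amide group of compound 3 is larger than that of compound 2 and gives a lower number, so a small step toward a lower number, or none beyond the scatter, is expected. The expected step is a 1.3-fold lower number from compound 2 to compound 4 (0.11 log units; within the scatter). Compound 4 is estimated at 100 nM in this assay, with a range from 30 nM to 350 nM.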

Compound 4, inhibition constant: 5.4 nM
Estimate against measurement, compound 4: 19-fold (1.27 log units) above; measured number outside the range, below it.
By their numbers in this assay, from the lowest: compound 4; then compound 3; then compound 2; then compound 1.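

Among the compounds shown here, on the shared core, the group on the carbonyl carbon can move this read-out much further than the earlier compounds showed: in this assay, 2-fluorocyclopropyl in place of isopropyl gives a 24-fold lower number from compound 2 to compound 4 (1.38 log units; beyond the scatter) as the first step that can be read at this position. The position therefore accepts a three-membered ring carrying fluorine, and with a large gain over the ringless isopropyl. No measurement on hand gives a cause for this step.

For the compounds shown here, the single step changes the ring, the fluorine and the stereocentres together, so their shares stay unresolved, and a plain cyclopropyl on the shared core or the opposite stereoisomers would be needed to separate them. From the compounds shown here alone, whether the gain extends to other groups at this position, such as chlorocyclopropyl or tert-butyl, also remains open.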